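A few compounds are considered here, and "the series" means these few. Any claim that something is new, unique, unknown or untested is made for them only; others in the source may bear on it.

In a functional assay on SMMC-7721 cells (Homo sapiens) for inhibition, read by CCK-8 assay, with a stated time of 72 h, tested at 2 uM (on this read-out higher numbers stand for more inhibition of growth at the one concentration tested and lower numbers for less inhibition of growth), compound 1 `Nc1ccccc1NC(=O)/C=C/c1ccc(CSc2ccc(Cl)cc2)cc1` gives 15.2%, which sits at the low end of the three numbers available. Compound 3 `Nc1ccccc1NC(=O)c1ccc(CSc2cccc(F)c2)cc1` gives 18.6%, within the scatter of compound 1. Compound 2 `CCc1ccc(SCc2ccc(C(=O)Nc3ccccc3N)cc2)cc1` gives 25.7%, higher than compound 1 and beyond the scatter.

The unmeasured compound 4 `Nc1ccccc1NC(=O)/C=C/c1ccc(CSc2ccc(C(F)(F)F)cn2)cc1` keeps the core of compound 1 and changes only the aromatic group on the sulfur: 5-(trifluoromethyl)pyridin-2-yl in place of 4-chlorophenyl on a sulfur. Within the data shown here, one measured step bears on a change at this place: a number 7.1 percentage points lower from compound 2 to compound 3 (within the scatter). That swap replaces one aromatic group on a sulfur with another and stays within the scatter. It is weak guidance, however, since compound 2 and compound 3 share a core that differs from the core of compound 1. Among the measured compounds shown here, no measured compound carries 5-(trifluoromethyl)pyridin-2-yl either, so the data give no direct reading for this group. On this evidence, no step beyond the scatter is expected in this assay, and no direction can be favoured with confidence. The expected step is a number 2.8 percentage points higher from compound 1 to compound 4 (within the scatter). For compound 4 the estimated value is 18%, with an expected range from 7% to 32%.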

Compound 4, percent growth inhibition at one concentration: 12.1%
Estimate against measurement, compound 4: 5.9 percentage points above, within the range that was stated.
By their numbers in this assay, from the lowest: compounds 4, 1, 3 and 2 (each within the scatter of the next, the first and the last beyond it).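

In this assay, among these compounds, the first direct change of the aromatic group on the sulfur on the core of compound 1 gives a number 3.1 percentage points lower from compound 1 to compound 4 (within the scatter), so 5-(trifluoromethyl)pyridin-2-yl in place of 4-chlorophenyl does not separate the two compounds on this read-out. Among the compounds shown here, until now the only step at this place came from another core, and this one shows that a ring with a hetero atom and a larger group, with one hydrogen-bond acceptor where the leaving group has none, can enter on the core of compound 1 without a step beyond the scatter. No measurement accompanies this result that could explain the step.

Open, as far as these compounds go, is whether a cyclohexyl ring or a longer alkyl chain on the sulfur, or an aromatic ring carrying an amine or a carboxylic acid, would produce a step beyond the scatter on the core of compound 1. Also open, from the compounds shown here alone, is whether 4-ethylphenyl, the group of compound 2 at 25.7% on its own core, would give a different number on the core of compound 1.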